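The source may hold more compounds than are shown below. What is called first, only, known or untested is meant among the compounds shown, and "the series" means these compounds.

Three compounds of the series share one core and differ only in the aryl group carried on the ring nitrogen. Compound 1 `Cc1ccccc1Nc1ncnc2cc(NC(=O)CCCCCCC(=O)NO)sc12` gives 87.6 nM in an assay on cells for inhibition of protein deacetylase HDAC6 (Homo sapiens), with a stated time of 3 h; on this read-out lower numbers stand for stronger inhibition and higher numbers for weaker inhibition. Compound 2 `Cc1cc(F)ccc1Nc1ncnc2cc(NC(=O)CCCCCCC(=O)NO)sc12` gives 120 nM in the same read-out, and compound 3 `COc1ccc(Nc2ncnc3cc(NC(=O)CCCCCCC(=O)NO)sc23)c(C)c1` gives 111 nM. The three single-point steps are all small: a 1.4-fold higher number from compound 1 to compound 2 (0.14 log units; within the scatter), a 1.3-fold higher number from compound 1 to compound 3 (0.10 log units; within the scatter) and a 1.1-fold lower number from compound 2 to compound 3 (0.03 log units; within the scatter). Compound 2 stands highest of the three numbers, yet within the scatter of both compound 3 and compound 1, so no order among them can be claimed.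

Compound 4 `CCc1ccc(Nc2ncnc3cc(NC(=O)CCCCCCC(=O)NO)sc23)cc1` has not been measured. Against compound 2 the change is 4-ethylphenyl in place of 4-fluoro-2-methylphenyl on a nitrogen on an aromatic ring. Among the measured compounds shown here, no measured step covers this replacement; the steps that bear on it are those that swap substituents on the same aryl ring, and each of them lies within the scatter. On that basis no step beyond the scatter is expected in this assay for compound 4, in either direction, with the range kept wide since the pair 2 to 4 exchanges the whole aryl group rather than one substituent. The expected step from compound 2 is a 1.1-fold lower number from compound 2 to compound 4 (0.04 log units; within the scatter). Compound 4 is estimated at 110 nM, with a range from 50 nM to 250 nM.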

Compound 4, half-maximal inhibitory concentration: 98.3 nM
Estimate against measurement, compound 4: 1.1-fold (0.05 log units) above, within the range that was stated.
By their numbers in this assay, from the lowest: compounds 1, 4, 3 and 2 (each within the scatter of the next).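

Up to this point the series varied only a substituent on a 2-methylphenyl group, whereas compound 4 exchanges that group for 4-ethylphenyl on the same nitrogen, a larger exchange of equal heavy-atom count in which the fluorine of compound 2 gives way to carbon alone. In this assay this exchange stays within the scatter against each of the other three compounds (a 1.2-fold lower number from compound 2 to compound 4 (0.09 log units; within the scatter)) (a 1.1-fold lower number from compound 3 to compound 4 (0.05 log units; within the scatter)) (a 1.1-fold higher number from compound 1 to compound 4 (0.05 log units; within the scatter)), so among these four compounds the 2-methyl group is not needed for a number in this range, and the four cannot be ordered. Nothing at hand bears on why the read-out stays so flat across these aryl groups.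

As far as these compounds go, it remains open whether this tolerance extends to an aryl group carrying an amine or a carboxylic acid, or to a longer chain in place of the ethyl group, since all four groups here hold only carbon, fluorine or methoxy substituents. From the compounds shown here alone, it is equally open how the number responds to a shorter or longer chain leading to the hydroxamic acid, which is identical in all four compounds.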